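A few compounds are considered here, and "the series" means these few. Any claim that something is new, unique, unknown or untested is made for them only; others in the source may bear on it.

Among the compounds with values here, compound 1 `Nc1cccc(CNc2cc(C(F)(F)F)cc3[nH]ncc23)c1` is the only compound here with a numerical result in an assay for inhibition of Tryptophan 2,3-dioxygenase (Homo sapiens), with stated times of 10 min and 60 min (a lower number here means a stronger inhibitor, a higher number a weaker inhibitor), where compound 1 gives 2510 nM. Compound 2 `FC(F)(F)c1cc(NCc2cccc3sccc23)c2cn[nH]c2c1` is reported in this assay only as a limit, > 100000 nM, which is the limit of > 100000 nM in this assay, at which 1 of the 2 values shown sits. Compound 3 `FC(F)(F)c1cc(NCc2cccc(Br)c2)c2cn[nH]c2c1` differs from compound 1 in a single place: bromo in place of amino on an aromatic carbon. Within the data shown here, no measured pair shows this change, so its effect in this assay is unknown. A modest weakening, somewhat beyond the scatter, is expected, giving an expected step of a 2.0-fold higher number from compound 1 to compound 3 (0.30 log units; within the scatter). Compound 3 is therefore estimated at 5000 nM, with a likely range from 1000 nM to 30000 nM.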

Compound 3, half-maximal inhibitory concentration: 19100 nM
Estimate against measurement, compound 3: 3.8-fold (0.58 log units) below; measured number inside the range.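

Within the data shown here, exchanging amino for bromo on this aromatic carbon gives a 7.6-fold higher number from compound 1 to compound 3 (0.88 log units; beyond the scatter) in this assay and is the first measured change at this place. The 3-aminophenyl compound therefore holds the stronger value, while compound 3 still gives a numerical result, not a limit. Nothing shown here accounts for the size of this step. As far as these compounds go, with only these two groups compared, it stays open whether the change follows from losing amino or from gaining bromo. A hydroxyl, a methyl or a chlorine in this place could help separate the two.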